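Swapping the aryl ether while keeping the rest unchanged

The source may hold more compounds than are shown below. What is called first, only, known or untested is meant among the compounds shown, and "the series" means these compounds.

Compound 1 `COc1ccc(F)cc1CNCCCNc1ccnc2cc(Oc3cccc(N(C)C)c3)ccc12` and compound 2 `COc1ccc(Oc2ccc3c(NCCCNCc4cccc(OC)c4O)ccnc3c2)cc1` share the same core and were both examined in a physicochemical assay for acid dissociation. In this assay compound 1 gives 9.28. In this assay compound 2 gives 9.28, level with compound 1 at the digits shown, so the two values lie within the usual scatter of each other and no order can be read from them. Among the compounds with values here, no two measured compounds differ in only one place, so no single step has yet been measured.

Compound 3 `COc1cccc(CNCCCNc2ccnc3cc(Oc4cccc(N(C)C)c4)ccc23)c1O` has not yet been measured. It differs from compound 2 in one place: 3-(dimethylamino)phenyl in place of 4-methoxyphenyl on an oxygen on an aromatic ring. Within the data shown here, the group that enters is the one compound 1 already carries, and compound 1 in this assay gives 9.28, which sits level with compound 2. The step is therefore expected to be none beyond the scatter, estimated as no change at the digits printed from compound 2 to compound 3 (within the scatter). Compound 3 is expected to give 9.28, with a range from 8.95 to 9.6.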

Compound 3, acid dissociation constant: 9.28
Compound 3: middle estimate and measured number agree at the digits printed, within the range that was stated.
By their numbers in this assay, from the lowest: compounds 1, 2 and 3 (each within the scatter of the next).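

In this assay, the exchange of 4-methoxyphenyl for 3-(dimethylamino)phenyl on an oxygen on an aromatic ring can now be read as a single step, and it shows no change at the digits printed from compound 2 to compound 3 (within the scatter). The second single step, 2-hydroxy-3-methoxyphenyl in place of 5-fluoro-2-methoxyphenyl on a saturated chain carbon bound to an amine nitrogen, shows no change at the digits printed from compound 1 to compound 3 (within the scatter), so neither change, taken alone, moves this number beyond the scatter, something the first two compounds could not show, as they differ in both places at once. Nothing measured here says what sets this number or which part of the molecule gives up the proton.

Still open, from the compounds shown here alone, is whether the level reading would hold with a carboxylic acid on the ring attached through the oxygen, or with a longer chain in place of the present saturated chain. Going by these compounds, these two steps also speak only for this one read-out, so how the same changes would appear in any other kind of test remains unknown.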